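This account rests on a few compounds, and the source may have more. Where it says the series, first, only, none or still open, it means among the compounds named here.

Measured so far:

Compound 1, `C=CC(=O)Nc1cccc(Oc2nc(Nc3ccc(OC)cc3)nc3c2CSCC3)c1`, gives > 50000 nM in an ADME assay on L02 cells (Homo sapiens) for cytotoxicity, read by MTT assay, with a stated time of 72 h (a lower number here means a stronger inhibitor, a higher number a weaker inhibitor), which is a limit of the assay rather than a number.
Compound 2, `C/C=C/C(=O)Nc1cccc(Oc2nc(Nc3ccc(OC)cc3)nc3c2CSCC3)c1`, gives > 50000 nM in this assay, again a limit.
Compound 3, `C=CC(=O)Nc1cccc(Oc2nc(Nc3ccc(OC)nc3)nc3c2CSCC3)c1`, gives > 50000 nM in this assay, again a limit.

The three compounds share one core and differ in two places. The change from compound 1 to compound 2 is prop-1-en-1-yl in place of vinyl on a carbonyl carbon. Because (the limit of > 50000 nM in this assay, at which 3 of the 3 values shown sit), the step that the two limits leave unreadable from compound 1 to compound 2. Compound 3 differs from compound 1 in the core: 6-methoxypyridin-3-yl in place of 4-methoxyphenyl on a nitrogen on an aromatic ring. Here too the step that the two limits leave unreadable from compound 1 to compound 3. Nothing in these three values separates one compound from another.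

Compound 4, `C/C=C/C(=O)Nc1cccc(Oc2nc(Nc3ccc(OC)nc3)nc3c2CSCC3)c1`, has not yet been measured in this assay. It differs from compound 3 by prop-1-en-1-yl in place of vinyl on a carbonyl carbon. This is the same change as from compound 1 to compound 2, on the same kind of place, now carried out on the core of compound 3. For compound 4 the step expected is a step that the limit leaves unreadable from compound 3 to compound 4. This expectation rests on the measured matching change, a step that the two limits leave unreadable from compound 1 to compound 2, and on (the limit of > 50000 nM in this assay, at which 3 of the 3 values shown sit). Compound 4 is therefore estimated at 70000 nM, with a plausible range from 25000 nM to 250000 nM, and the most likely outcome is that the assay again reports only a limit.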

Compound 4, half-maximal inhibitory concentration: > 50000 nM
Compound 4 gave a limit, no number (the forecaster's own chance of this, stated with the estimate: 85%); the middle value lies beyond the limit too.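

No step can be read from compound 3 to compound 4 or from compound 2 to compound 4, because these results are limits of the assay and not numbers: the limit of > 50000 nM in this assay, at which 4 of the 4 values shown sit.

The compounds shown leave open how the four compare in this assay, and whether prop-1-en-1-yl in place of vinyl or 6-methoxypyridin-3-yl in place of 4-methoxyphenyl changes the read-out at all.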